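Chain extension from compound 2 to compound 3

A few compounds are considered here, and "the series" means these few. Any claim that something is new, unique, unknown or untested is made for them only; others in the source may bear on it.

In a functional assay on UMUC3 cells (Homo sapiens) for antiproliferative activity, read by MTT assay, with a stated time of 72 h (a lower number here means a stronger inhibitor, a higher number a weaker inhibitor), compound 1 (`CC(C)CNC(=N)NC(=N)Nc1ccc(C(F)(F)F)cc1`) gives 2000 nM and compound 2 (`CC(C)CNC(=N)NC(=N)Nc1ccc(F)c(F)c1`) gives 7100 nM as its number. Compound 2 therefore stands highest of the two, and its gap to compound 1 lies beyond the scatter. Compound 3 (`CCCCCCCNC(=N)NC(=N)Nc1ccc(F)c(F)c1`) keeps the core of compound 2 and alters only the chain: hexyl in place of isopropyl on a saturated chain carbon bound to an amine nitrogen. Among the measured compounds shown here, no measured pair shows a chain change, so the direction is a judgement without direct support. A moderate move to a lower number, beyond the scatter, is expected in this assay, with a 2.8-fold lower number from compound 2 to compound 3 (0.45 log units; beyond the scatter) as the estimated step. For the measured compounds named here, compound 1 at 2000 nM is the only guide so far to how low the series reaches. The estimate for compound 3 is 2500 nM, with an expected range from 1000 nM to 6000 nM in this read-out.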

Compound 3, half-maximal inhibitory concentration: 2100 nM
Estimate against measurement, compound 3: 1.2-fold (0.08 log units) above, within the range that was stated.
By their numbers in this assay, from the lowest: compounds 1 and 3 (each within the scatter of the next); then compound 2.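

Among the compounds shown here, this is the first chain change, and it shows that the chain position affects the number in this assay (a modest step: a 3.4-fold lower number from compound 2 to compound 3 (0.53 log units; beyond the scatter)), with the hexyl group accepted on the core of compound 2 without any loss of activity. Because hexyl differs from isopropyl in both length and branching, this single step cannot separate the two, and the data do not show which of them matters. No measurement on hand explains the step.

Still open, on these data alone, is whether the number keeps falling, levels off or rises with an octyl chain, and whether a cyclohexyl group or a chain ending in an amine would be accepted at the same place. As far as these compounds go, it is also open whether hexyl gives a similar step on the core of compound 1, which carries a trifluoromethyl group.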